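Fluoro to methyl on compound 3

A few compounds are considered here, and "the series" means these few. Any claim that something is new, unique, unknown or untested is made for them only; others in the source may bear on it.

Compound 1 `Fc1ccc2[nH]c(-c3cn(-c4ccccc4)nc3-c3ccccc3)nc2c1` reads 3610 nM in a functional assay on HeLa cells (Homo sapiens) for antiproliferative activity, read by MTT assay, with a stated time of 48 h (on this read-out higher numbers stand for weaker inhibition and lower numbers for stronger inhibition), and compound 2 `Cc1ccc2[nH]c(-c3cn(-c4ccccc4)nc3-c3ccccc3)nc2c1` reads 6560 nM there, two values within the scatter of each other. Compound 3 `COc1ccc(-c2nn(-c3ccccc3)cc2-c2nc3cc(F)ccc3[nH]2)cc1` reads 1740 nM on the same read-out, the lowest of the three numbers and beyond the scatter from both of the others. Compound 4 `COc1ccc(-c2nn(-c3ccccc3)cc2-c2nc3cc(C)ccc3[nH]2)cc1` has not yet been measured. It differs from compound 3 by methyl in place of fluoro on an aromatic carbon of a six-membered aromatic ring of carbon only, part of a fused or bridged system of two rings. One measured step, a 2.1-fold lower number from compound 1 to compound 3 (0.32 log units; beyond the scatter) for methoxy in place of hydrogen on an aromatic carbon, is modest and only accounts for the starting level of compound 3, not for the exchange itself. Among the compounds with values here, the one measured step with the same exchange is a 1.8-fold higher number from compound 1 to compound 2 (0.26 log units; within the scatter) in a pair without the methoxy group, so a similar small move toward a higher number is expected in this assay and may stay within the scatter. Within the data shown here, that single pair is the only guide, and the exchange remains untested with the methoxy group present. The estimated change is a 1.7-fold higher number from compound 3 to compound 4 (0.24 log units; within the scatter) on this reasoning. Compound 4 is therefore estimated at 3000 nM with an expected range of 1500 nM to 6000 nM for repeated measurements.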

Compound 4, half-maximal inhibitory concentration: 3290 nM
For compound 4 the middle estimate is 1.1-fold (0.04 log units) below the measured one; measured number inside the range.
By their numbers in this assay, from the lowest: compounds 3, 4, 1 and 2 (each within the scatter of the next, the first and the last beyond it).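

In this assay, methyl in place of fluoro with the methoxy group present gives a 1.9-fold higher number from compound 3 to compound 4 (0.28 log units; within the scatter), so this exchange at the aromatic carbon can now be read on a second core, and it matches the reading without the methoxy group: the same change on two cores in this assay, a 1.8-fold higher number (0.26 log units; within the scatter) from compound 1 to compound 2 and a 1.9-fold higher number (0.28 log units; within the scatter) from compound 3 to compound 4, 1.0-fold (0.02 log units) apart, within the scatter of two such steps. The methoxy exchange can likewise now be read with methyl rather than fluoro on that carbon, where it gives a 2.0-fold lower number from compound 2 to compound 4 (0.30 log units; within the scatter), much the same as with fluoro: the same change on two cores in this assay, a 2.1-fold lower number (0.32 log units; beyond the scatter) from compound 1 to compound 3 and a 2.0-fold lower number (0.30 log units; within the scatter) from compound 2 to compound 4, 1.0-fold (0.02 log units) apart, within the scatter of two such steps. Across these four compounds, none of which goes against it, the two changes therefore appear to act independently of each other, although both fluoro-to-methyl steps lie within the scatter, so the compounds establish no preference between fluoro and methyl at this position.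

The compounds shown leave open how this aromatic carbon would read with an amine or a carboxylic acid, as fluoro and methyl are the only groups seen there. They also leave open whether the independence of the two changes would hold with a methoxy group replaced by a longer chain such as butoxy.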